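The source may hold more compounds than are shown below. What is called first, only, known or untested is meant among the compounds shown, and "the series" means these compounds.

Working notes on the series. The shared core of compound 1 `CCOc1ccc2c(=O)c(-c3ccc(O)cc3)coc2c1` carries a short alkoxy chain on the aromatic ring; in an assay on isolated protein (Cricetulus griseus) for inhibition of aldehyde dehydrogenase, mitochondrial (Homo sapiens) (on this read-out higher numbers stand for weaker inhibition and lower numbers for stronger inhibition), compound 1 gives 40 nM. Compound 2 `O=c1c(-c2ccc(O)cc2)coc2cc(OCCC3OCCCO3)ccc12` extends that chain with a saturated six-membered ring bearing two oxygens, and in this assay compound 2 gives 400 nM; the step of a 10-fold higher number from compound 1 to compound 2 (1.00 log units; beyond the scatter) is the largest shift recorded. Compound 3 `O=c1c(-c2ccc(O)cc2)coc2cc(OCCCBr)ccc12` instead ends the chain in a bromine, and in this assay compound 3 gives 260 nM, the second highest of the three numbers; its step of a 6.5-fold higher number from compound 1 to compound 3 (0.81 log units; beyond the scatter) is the one that bears most on what follows, while the comparison a 1.5-fold lower number from compound 2 to compound 3 (0.19 log units; within the scatter) shows the two longer chains indistinguishable.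

Compound 4 `C=CCOc1ccc2c(=O)c(-c3ccc(O)cc3)coc2c1` is reached from compound 3 by the change (vinyl in place of 2-bromoethyl on a saturated chain carbon bound to an oxygen on an aromatic ring). It removes the bromine-bearing portion that distinguishes compound 3 from compound 1 and leaves a chain ending in a double bond, so it sits structurally between compound 1 and compound 3. Since the step of a 6.5-fold higher number from compound 1 to compound 3 (0.81 log units; beyond the scatter) was modest and is largely undone here, the expected movement a 3.3-fold lower number from compound 3 to compound 4 (0.51 log units; beyond the scatter) is back toward compound 1 but not fully. Compound 4 is therefore estimated at 80 nM, in the range 30 nM to 250 nM.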

Compound 4, half-maximal inhibitory concentration: 800 nM
Compound 4: the middle estimate sits 10-fold (1.00 log units) below what was measured; the whole stated range lies below it.
By their numbers in this assay, from the lowest: compound 1; then compounds 3, 2 and 4 (each within the scatter of the next, the first and the last beyond it).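

Within the ethers shown, the smallest structural change gives the largest step: vinyl in place of methyl on the saturated chain carbon gives a 20-fold higher number from compound 1 to compound 4 (1.30 log units; beyond the scatter). Cutting 3-bromopropoxy back to allyloxy therefore does not return the number toward that of compound 1, but moves it the other way, with a 3.1-fold higher number from compound 3 to compound 4 (0.49 log units; beyond the scatter), so a shorter chain alone does not recover the inhibition seen with compound 1, and the allyl chain is no better placed than the longer ones; the step of a 2.0-fold higher number from compound 2 to compound 4 (0.30 log units; within the scatter) leaves allyl and the chain bearing the six-membered ring with two oxygens indistinguishable in this series. Nothing available on this series accounts for the result.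

Still open, going by these compounds, is whether the double bond itself or the added chain carbon goes with the large step from compound 1, a question that a saturated propyl group in place of allyl would separate. Also open, on these data alone, is how a chain ending in a hydroxyl group or a carboxylic acid would compare with the chain ending in bromine and with the short ethyl ether of compound 1.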